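The source may report more compounds than this note shows. Statements on the series, on what has been measured and on what is new or still open speak of the compounds shown alone.

Measured so far:
compound 1, `Cc1ccn2c(Nc3ccccn3)c(-c3ccccn3)nc2c1`: > 50000 nM
compound 2, `Cc1ccn2c(Nc3ccc(F)cc3)c(-c3ccccn3)nc2c1`: 5900 nM
compound 3, `Oc1ccn2c(Nc3cccc(F)c3)c(-c3ccccn3)nc2c1`: 43300 nM

In an ADME assay on THP-1 cells (Homo sapiens) for cytotoxicity (a lower number here means that less compound is tolerated, a higher number that more compound is tolerated), compound 1 gives only > 50000 nM, which is a limit of the assay rather than a number (the limit of > 50000 nM in this assay, at which 1 of the 3 values shown sits). Compound 2 gives 5900 nM. For the measured compounds named here, compound 3 gives 43300 nM, the highest of the two numbers, a gap beyond the scatter from compound 2; these two differ in more than one place, so no single step links them. Going by the values given here, the one measured step, an at least 8.4-fold lower number from compound 1 to compound 2 (0.92 log units; beyond the scatter), concerns the group on the ring nitrogen, not the position changed here. Compound 4, `Cc1ccn2c(Nc3cccc(F)c3)c(-c3ccccn3)nc2c1`, differs from compound 3 by methyl in place of hydroxy on an aromatic carbon. Among the compounds with values here, no measured step bears on this change, so compound 4 is expected to move only modestly, the estimated step being a 2.2-fold lower number from compound 3 to compound 4 (0.34 log units; beyond the scatter). Compound 4 is estimated at 20000 nM, between 5000 nM and 50000 nM.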

Compound 4, half-maximal cytotoxic concentration: 14200 nM
Compound 4: middle estimate off by 1.4-fold (0.15 log units), on the high side; the measured number falls inside the stated range.
By their numbers in this assay, from the lowest: compound 2; then compound 4; then compound 3. At a limit, above all of these: compound 1.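

In this assay, the position opposite the ring nitrogen now has a measured step, with methyl in place of hydroxy: a 3.0-fold lower number from compound 3 to compound 4 (0.48 log units; beyond the scatter). The group on the nitrogen also matters with methyl in this position, as 3-fluorophenyl in place of 4-fluorophenyl gives a 2.4-fold higher number from compound 2 to compound 4 (0.38 log units; beyond the scatter), and 3-fluorophenyl in place of pyridin-2-yl gives an at least 3.5-fold lower number from compound 1 to compound 4 (0.54 log units; beyond the scatter). The value of compound 1 in that last step is a limit and not a number: the limit of > 50000 nM in this assay, at which 1 of the 4 values shown sits.

The compounds shown carry only hydroxy and methyl at this position. From the compounds shown here alone, how an amine, a methoxy group or a longer chain there would read remains open.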